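Notes on the amine side chain, compound 1 to compound 4

The compounds below may be only part of what the source reports. "The series", "measured", "known", "first", "only" and "open" are said of these compounds alone.

- compound 1 `CCCCS(=O)(=O)Nc1cc(-c2ccc3ncnc(NCc4ccncc4)c3c2)cnc1OC` gives 8980 nM in this series
- compound 2 `COc1ncc(-c2ccc3ncnc(NCc4ccncc4)c3c2)cc1NS(=O)(=O)c1ccc(F)cc1F` gives 12400 nM in this series
- compound 3 `COc1ncc(-c2ccc3ncnc(NCCN(C)C)c3c2)cc1NS(=O)(=O)c1ccc(F)cc1F` gives 4720 nM in this series

In a functional assay on SK-HEP1 cells (Homo sapiens) for antiproliferative activity, read by sulforhodamine B assay, with a stated time of 72 h (a higher number here means a weaker inhibitor, a lower number a stronger inhibitor), the value of compound 1 lies within the usual scatter of the values of both compound 2 and compound 3, so it cannot be ranked against either.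

Compound 4 `CCCCS(=O)(=O)Nc1cc(-c2ccc3ncnc(NCCCN(C)C)c3c2)cnc1OC` keeps the core and the butyl group on the sulfonyl sulfur of compound 1. The change is 2-(dimethylamino)ethyl in place of pyridin-4-yl on a saturated chain carbon bound to a nitrogen on an aromatic ring and, in words, 2-(dimethylamino)ethyl replaces pyridin-4-yl on a saturated chain carbon bound to a nitrogen on an aromatic ring.

Within the data shown here, two measured steps bear on this. The step of a 1.4-fold higher number from compound 1 to compound 2 (0.14 log units; within the scatter) shows no separable effect of exchanging butyl for 2,4-difluorophenyl on a sulfonyl sulfur, which leaves some room to carry a side-chain step across the two sulfonyl groups. The closer precedent is a 2.6-fold lower number from compound 2 to compound 3 (0.42 log units; beyond the scatter) with (dimethylamino)methyl entering in place of pyridin-4-yl. That is one modest step with a different entering group, so the transfer is uncertain.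

A modest step towards a lower number is therefore expected in this assay and it may not clear the scatter. The expected change is a 2.4-fold lower number from compound 1 to compound 4 (0.37 log units; beyond the scatter) on this reasoning. For compound 4 the estimate is 3800 nM with an expected range from 1500 nM to 9500 nM as the working interval.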

Compound 4, half-maximal inhibitory concentration: 860 nM
The estimate for compound 4 lay 4.4-fold (0.65 log units) above the measured number; the measured number lies below the stated range.
By their numbers in this assay, from the lowest: compound 4; then compounds 3, 1 and 2 (each within the scatter of the next, the first and the last beyond it).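

In this assay the amine side chain gives a 10-fold lower number from compound 1 to compound 4 (1.02 log units; beyond the scatter) as 2-(dimethylamino)ethyl replaces pyridin-4-yl on a saturated chain carbon bound to a nitrogen on an aromatic ring, so with butyl on the sulfonyl sulfur this position carries a large step. The earlier side-chain exchange reached only a 2.6-fold lower number from compound 2 to compound 3 (0.42 log units; beyond the scatter) with (dimethylamino)methyl entering and 2,4-difluorophenyl on the sulfonyl sulfur, and since the two steps differ in both the entering group and the sulfonyl group, neither difference can be singled out as setting their size. Nothing measured here accounts for the size of the new step.

Still open, on these data alone, is whether 3-(dimethylamino)propyl gives a step of this size with 2,4-difluorophenyl on the sulfonyl sulfur, which would separate the chain from the sulfonyl group. Also open, as far as these compounds go, is how far the trend in chain and end group extends, for example to a longer chain such as 4-(dimethylamino)butyl, or to a ring amine such as morpholine or piperidine at the end of the 3-carbon propyl chain.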